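Estimating a methoxycarbonyl on the phenoxy of compound 3

The source may report more compounds than this note shows. Statements on the series, on what has been measured and on what is new or still open speak of the compounds shown alone.

Three compounds share a core and differ only at the group on the nitrogen-bound oxygen. Compound 1 `CCCCCON1C(=O)[C@@H](NC(=O)OCCCCC2CCCCC2)[C@@H]1C` gives 387 nM in an assay on HEK293 cells for inhibition of N-acylethanolamine-hydrolyzing acid amidase (Homo sapiens), read by fluorescence, with stated times of 10 min and 50 min; a higher number here means a weaker inhibitor, a lower number a stronger inhibitor. Compound 2 `CSCCCON1C(=O)[C@@H](NC(=O)OCCCCC2CCCCC2)[C@@H]1C` gives 167 nM, and the step of a 2.3-fold lower number from compound 1 to compound 2 (0.36 log units; beyond the scatter) is modest. Compound 3 `C[C@H]1[C@H](NC(=O)OCCCCC2CCCCC2)C(=O)N1Oc1ccccc1` gives 23 nM, the lowest of the three numbers, separated from both others by steps beyond the scatter: a 17-fold lower number from compound 1 to compound 3 (1.23 log units; beyond the scatter) and a 7.3-fold lower number from compound 2 to compound 3 (0.86 log units; beyond the scatter).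

Compound 4 `COC(=O)c1ccc(ON2C(=O)[C@@H](NC(=O)OCCCCC3CCCCC3)[C@@H]2C)cc1` differs from compound 3 by methoxycarbonyl in place of hydrogen on an aromatic carbon. Within the data shown here, no measured step alters a substituent on the aromatic ring itself; the steps from compound 1 and compound 2 to compound 3 concern only the replacement of a chain by phenyl on that oxygen, so they show the group at this position matters but say nothing about decorating the phenyl. The expected step is therefore uncertain and estimated to lie within or near the scatter, a 1.0-fold lower number from compound 3 to compound 4 (0.02 log units; within the scatter). Compound 4 is estimated at 22 nM, with a range from 5 nM to 90 nM.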

Compound 4, half-maximal inhibitory concentration: 17 nM
Estimate against measurement, compound 4: 1.3-fold (0.11 log units) above, and the stated range covers the measured number.
By their numbers in this assay, from the lowest: compounds 4 and 3 (each within the scatter of the next); then compound 2; then compound 1.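

In this assay a methoxycarbonyl on an aromatic carbon, para to a large group, gives a 1.4-fold lower number from compound 3 to compound 4 (0.13 log units; within the scatter) and the two numbers cannot be told apart. This shows that the phenyl on this oxygen accepts a substituent of 4 heavy atoms at this place with no difference beyond the scatter. The 4-(methoxycarbonyl)phenyl group also stays clearly apart from both chains on that oxygen, with a 9.8-fold lower number from compound 2 to compound 4 (0.99 log units; beyond the scatter) and a 23-fold lower number from compound 1 to compound 4 (1.36 log units; beyond the scatter) in the same assay. Nothing available bears on why this substituent is accepted.

The compounds shown leave open whether a carboxylic acid, an amine or a chlorine atom at the same place would give a similar number. They also leave open how a methoxycarbonyl would fare on any other carbon of the ring.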